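Dropping the chloro from the sulfonyl aryl ring

The compounds below may be only part of what the source reports. "The series", "measured", "known", "first", "only" and "open" are said of these compounds alone.

Compound 1 `CCCCOC(=O)Nc1ccc2cnn(Cc3ccc(C(=O)NS(=O)(=O)c4ccccc4)cc3OC)c2c1`: 9.2
Compound 2 `COc1cc(C(=O)NS(=O)(=O)c2c(C)cccc2Cl)ccc1Cn1ccc2ccc(NC(=O)CC3CCCC3)cc21`: 8.8

Of the compounds shown here, two have been measured in a functional assay (trachea) for antagonist activity, with Cavia porcellus as the target; a higher number here means a more potent compound, by a factor of ten per unit of this negative logarithm, a lower number a less potent compound. Compound 2 stands lowest of the two numbers; its nearest neighbour, compound 1, lies higher by a gap beyond the usual scatter. Compound 3 `COc1cc(C(=O)NS(=O)(=O)c2ccccc2C)ccc1Cn1ccc2ccc(NC(=O)CC3CCCC3)cc21` differs from compound 2 in one place: hydrogen in place of chloro on an aromatic carbon, so that the (2-chloro-6-methylphenyl)sulfonyl group becomes a (2-methylphenyl)sulfonyl group. Among the measured compounds shown here, no measured pair shows this change, so the expectation rests on compound 2 and its 8.8 alone. A small loss is expected, the step from compound 2 to compound 3 estimated at a number 0.30 log units lower from compound 2 to compound 3 (within the scatter), which may yet fall within the scatter. Compound 3 is expected to give 8.5 in this assay, between 7.9 and 9.1.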

Compound 3, negative logarithm of the antagonist equilibrium constant: 9.9
Beside the measured number, compound 3's estimate is 1.40 log units below it; measured number above the stated range.
By their numbers in this assay, from the lowest: compound 2; then compound 1; then compound 3.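

In this assay hydrogen in place of chloro gives a number 1.10 log units higher from compound 2 to compound 3 (beyond the scatter) and so shows that this aromatic carbon, ortho to a large group, is sensitive to a single atom, with the (2-methylphenyl)sulfonyl group clearly ahead of the (2-chloro-6-methylphenyl)sulfonyl group on this core. Compound 1 and compound 2 differ in more than one place, so they could not show this. Nothing measured here bears on why the step is so large. The compounds shown leave open how a fluoro or methoxy group on that carbon would compare, and whether the same change would give a similar step on the core of compound 1.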